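This account rests on a few compounds, and the source may have more. Where it says the series, first, only, none or still open, it means among the compounds named here.

Compound 1 `CN1CCN(c2nc(-c3cc(Cl)ccc3Cl)nc3[nH]cnc23)CC1` is the reference point of the series. In an assay on cells for displacement of a labelled ligand from adenosine receptor A1 (Homo sapiens), read by scintillation counting and radioligand binding, with a stated time of 60 min, tested at 10 uM (a higher number here means more inhibition at the concentration tested (going by the name of the read-out), a lower number less inhibition), compound 1 gives > 80%, which is a limit of the assay. Its position among the values is that of the limit of > 80% in this assay, at which 1 of the 2 values shown sits. Among the measured compounds shown here, compound 2 `Clc1ccc(Cl)c(-c2nc(N3CCCCC3)c3nc[nH]c3n2)c1` gives 1.4% in this assay, and the step of a number at least 78.6 percentage points lower from compound 1 to compound 2 (beyond the scatter) is the only measured change. Compound 3 `CN1CCN(c2nc(-c3ccc(O)cc3)nc3[nH]cnc23)CC1` is not yet measured in this assay. It differs from compound 1 in the aromatic group alone: 4-hydroxyphenyl in place of 2,5-dichlorophenyl on an aromatic carbon. For the measured compounds named here, the single measured step alters the amine, not this group, so no measured step bears directly on the change to compound 3; it shows only that one change can carry the read-out from the upper limit to a low value. Given that compound 1 stands at a limit, the expected step of a number at least 30 percentage points lower from compound 1 to compound 3 (beyond the scatter) is a moderate drop with wide uncertainty. Compound 3 is therefore estimated at 50%, between 10% and 85%.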

Compound 3, a percentage reported as inhibition, at one concentration (the size of the read-out at that concentration, not a potency): > 80%
Compound 3 gave a limit, no number (the forecaster's own chance of this, stated with the estimate: 20%); middle value at least 30 percentage points from the limit.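

In this assay compound 3 gives > 80% as a limit of the assay. Among the compounds shown here, compound 1 stands at the same limit, so no step between compound 1 and compound 3 can be read: the limit of > 80% in this assay, at which 2 of the 3 values shown sit. The compounds shown leave open whether 4-hydroxyphenyl and 2,5-dichlorophenyl differ at all in this assay.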